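Methoxy added to the methyl arm of compound 2

This account rests on a few compounds, and the source may have more. Where it says the series, first, only, none or still open, it means among the compounds named here.

Compound 1 `CCC(CC)CNc1c(C(N)=O)cnc2ccc(-c3ccnnc3)cc12` in an assay on HT-29 cells for inhibition of Serine-protein kinase ATM (Homo sapiens), read by fluorescence, with a stated time of 1 h; on this read-out higher numbers stand for weaker inhibition and lower numbers for stronger inhibition: 908 nM
Compound 2 `CCC(CC)CNc1c(C(N)=O)cnc2ccc(-c3ccc(C)nc3)cc12` in this assay: 50 nM

Among these two numbers compound 2 stands lowest; its only neighbour is compound 1, and the step of an 18-fold lower number from compound 1 to compound 2 (1.26 log units; beyond the scatter) is large. Compound 3 `CCC(CC)CNc1c(C(N)=O)cnc2ccc(-c3ccc(COC)nc3)cc12` differs from compound 2 by methoxy in place of hydrogen on a saturated chain carbon bound to an aromatic carbon. Going by the values given here, the one measured step, an 18-fold lower number from compound 1 to compound 2 (1.26 log units; beyond the scatter), exchanges an entire ring and leaves the methyl untouched, so no measured step bears on this change, and there is nothing to show a direction. The step of a 1.2-fold higher number from compound 2 to compound 3 (0.08 log units; within the scatter) is therefore expected to be none beyond the scatter. Compound 3 is estimated at 60 nM, within a range of 20 nM to 200 nM.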

Compound 3, half-maximal inhibitory concentration: 45 nM
Beside the measured number, compound 3's estimate is 1.3-fold (0.12 log units) above it; the range from low to high includes it.
By their numbers in this assay, from the lowest: compounds 3 and 2 (each within the scatter of the next); then compound 1.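

In this assay, methoxy on this saturated chain carbon gives a 1.1-fold lower number from compound 2 to compound 3 (0.05 log units; within the scatter) and so leaves compound 2 and compound 3 indistinguishable: this carbon can carry the extra group with no measurable shift. The advantage over pyridazin-4-yl also survives the new group, with a 20-fold lower number from compound 1 to compound 3 (1.30 log units; beyond the scatter) for the swap to 6-(methoxymethyl)pyridin-3-yl. No supporting data are available to explain either result.

On these data alone, whether this carbon would accept an amine, a carboxylic acid or a longer chain just as readily remains open.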